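This account rests on a few compounds, and the source may have more. Where it says the series, first, only, none or still open, it means among the compounds named here.

Compound 1 `CCN1CCN(CCCn2cnc3c(N4CCN(C5CCCC5)CC4)nc(NCc4ccc(F)cc4)nc32)CC1` belongs to a small set of analogues examined in an assay on HEK293 cells for antagonist activity at Toll-like receptor 9 (Homo sapiens), read by spectrophotometry (on this read-out lower numbers stand for stronger inhibition and higher numbers for weaker inhibition), where compound 1 gives 250 nM. Among the three numbers recorded, it stands second highest. Compound 2 `CCN1CCN(CCCn2cnc3c(N4CCN(CC)CC4)nc(NCc4ccc(F)cc4)nc32)CC1` gives 470 nM in this assay, and the step of a 1.9-fold higher number from compound 1 to compound 2 (0.27 log units; within the scatter), ethyl in place of cyclopentyl on an amine nitrogen in a ring, stays within the scatter. Compound 3 `Fc1ccc(CNc2nc(N3CCN(C4CCCC4)CC3)c3ncn(CCCN4CCCC4)c3n2)cc1` gives 100 nM in this assay, and the step of a 2.5-fold lower number from compound 1 to compound 3 (0.40 log units; beyond the scatter), pyrrolidin-1-yl in place of 4-ethylpiperazin-1-yl on a saturated chain carbon, is a modest change beyond the scatter. Compound 4 `CCN1CCN(CCCn2cnc3c(N4CCN(C5CCCC5)CC4)nc(NCc4ccc(N(CC)CC)cc4)nc32)CC1` has not yet been measured in this assay. It differs from compound 1 by diethylamino in place of fluoro on an aromatic carbon, on an aromatic carbon of a six-membered aromatic ring of carbon only, para to a large group. Neither measured step touches that ring, so nothing recorded bears directly on this change. Without a guide, compound 4 is estimated to sit near compound 1, at 300 nM with a range from 80 nM to 1200 nM. That estimate means an expected step of a 1.2-fold higher number from compound 1 to compound 4 (0.08 log units; within the scatter), likely not beyond the scatter.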

Compound 4, half-maximal inhibitory concentration: 150 nM
Compound 4: the middle estimate sits 2.0-fold (0.30 log units) above what was measured; the measured number falls inside the stated range.
By their numbers in this assay, from the lowest: compounds 3, 4, 1 and 2 (each within the scatter of the next, the first and the last beyond it).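

Going by these compounds alone, compound 4 is the first of these analogues to vary the six-membered aromatic ring of carbon only, and it does so on the aromatic carbon para to a large group. In this assay, diethylamino with 5 heavy atoms replaces fluoro with 1 heavy atom, yet the result is a 1.7-fold lower number from compound 1 to compound 4 (0.22 log units; within the scatter), so this single change, despite the added nitrogen and carbons, gives no difference that can be told from the scatter. No measurement available here accounts for this outcome.

The compounds shown leave open how other groups at this carbon would read, such as dimethylamino, methoxy or a carboxylic acid. They also leave open whether diethylamino would give a similar result alongside the pyrrolidin-1-yl group of compound 3.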